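Shortening the Alkylamino Group: From Isobutyl to Isopropyl

This account rests on a few compounds, and the source may have more. Where it says the series, first, only, none or still open, it means among the compounds named here.

Of the compounds shown here, three sharing one core have been tested in an assay on isolated protein for inhibition of Amine oxidase [flavin-containing] A (Homo sapiens), read by fluorescence and Amplex Red, with a stated time of 30 min, tested at 10 uM; on this read-out lower numbers stand for a weaker effect and higher numbers for a stronger effect at the one concentration tested. Compound 1 `C=CCNc1nnc(SCC(=O)N(Cc2cccc([N+](=O)[O-])c2)c2ccc(F)cc2)s1` gives 75.2%, compound 2 `CCCNc1nnc(SCC(=O)N(Cc2cccc([N+](=O)[O-])c2)c2ccc(F)cc2)s1` gives 78.3%, and compound 3 `CC(C)CNc1nnc(SCC(=O)N(Cc2cccc([N+](=O)[O-])c2)c2ccc(F)cc2)s1` gives 72.6%. Compound 3 sits lowest of the three, but the steps of a number 2.6 percentage points lower from compound 1 to compound 3 (within the scatter) and a number 5.7 percentage points lower from compound 2 to compound 3 (within the scatter) both lie within the scatter, so no real ordering can be claimed.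

Compound 4 `CC(C)Nc1nnc(SCC(=O)N(Cc2cccc([N+](=O)[O-])c2)c2ccc(F)cc2)s1` has not yet been measured. It differs from compound 3 by isopropyl in place of isobutyl on a nitrogen on an aromatic ring. For the measured compounds named here, every measured step so far changes the chain on this same nitrogen, and all stayed within the scatter, including a number 3.1 percentage points higher from compound 1 to compound 2 (within the scatter). A step of no size beyond the scatter is therefore expected for a number 2.4 percentage points higher from compound 3 to compound 4 (within the scatter). Compound 4 is estimated to give 75%, within a range from 65% to 83%.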

Compound 4, a percentage reported as inhibition, at one concentration (the size of the read-out at that concentration, not a potency): 86.1%
Compound 4: middle estimate off by 11.1 percentage points, on the low side; the whole stated range lies below it.
By their numbers in this assay, from the lowest: compounds 3, 1, 2 and 4 (each within the scatter of the next, the first and the last beyond it).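

Changing the chain on this nitrogen can shift the read-out after all: isopropyl in place of isobutyl gives a number 13.5 percentage points higher from compound 3 to compound 4 (beyond the scatter), and isopropyl in place of allyl gives a number 10.9 percentage points higher from compound 1 to compound 4 (beyond the scatter). Isopropyl in place of propyl, however, gives only a number 7.8 percentage points higher from compound 2 to compound 4 (within the scatter), so compound 4 cannot be separated from compound 2. Nothing available explains why isopropyl stands apart from isobutyl and allyl here.

On these data alone, whether a cyclopropyl or tert-butyl group on this nitrogen would give a similar number remains open. So does the outcome with a plain unsubstituted amine.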